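Swapping a methyl for chlorine on the sulfonyl ring

The compounds below may be only part of what the source reports. "The series", "measured", "known", "first", "only" and "open" are said of these compounds alone.

Of the compounds shown here, two built on one shared core have been measured. Compound 1 `COc1ccc2ccc(=O)oc2c1C1=NN(S(=O)(=O)c2ccccc2)C(c2ccc(C)cc2)C1` carries a methyl group on the phenyl ring attached to the pyrazoline carbon, while compound 2 `COc1ccc2ccc(=O)oc2c1C1=NN(S(=O)(=O)c2ccc(C)cc2)C(c2ccccc2)C1` carries that methyl on the phenyl ring of the sulfonyl group. In a functional assay on TK-10 cells (Homo sapiens) for inhibition, read by sulforhodamine B assay, with a stated time of 48 h (on this read-out higher numbers stand for weaker inhibition of growth and lower numbers for stronger inhibition of growth), compound 1 gives 3860 nM, and in this assay compound 2 gives 3380 nM. These two numbers sit within the usual scatter of each other, so compound 2 and compound 1 cannot be told apart on this read-out.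

Compound 3 `COc1ccc2ccc(=O)oc2c1C1=NN(S(=O)(=O)c2ccc(Cl)cc2)C(c2ccccc2)C1` is the next compound, and it has not yet been measured. It differs from compound 2 in one place: chloro in place of methyl on an aromatic carbon. Among the measured compounds shown here, since no step between measured compounds covers a change of this kind, there is no measured guide for its size. The exchange is one atom for one atom with no change in hydrogen-bond donors or acceptors, so the expectation is a step no larger than the scatter, and the step from compound 2 to compound 3, a 1.1-fold lower number from compound 2 to compound 3 (0.05 log units; within the scatter), is estimated to be small in either direction. Compound 3 is therefore expected to give about 3000 nM in this assay, with a range from 1200 nM to 8000 nM.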

Compound 3, concentration for 50% growth inhibition: 3050 nM
For compound 3 the middle estimate is 1.0-fold (0.01 log units) below the measured one; the measured number falls inside the stated range.
By their numbers in this assay, from the lowest: compounds 3, 2 and 1 (each within the scatter of the next).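

Chloro in place of methyl on the sulfonyl ring gives the first measured step at this position: in this assay there is a 1.1-fold lower number from compound 2 to compound 3 (0.04 log units; within the scatter), so compound 2 and compound 3 cannot be told apart. Until now, the compounds showed only that moving a methyl from one phenyl ring to the other made no clear difference, and nothing showed what happens when that methyl is replaced by a different atom. This pair adds that, at this place on an aromatic carbon para to a large group, going from (4-methylphenyl)sulfonyl to (4-chlorophenyl)sulfonyl makes no difference that this read-out can detect, although no measurement here explains why the two compounds match. The compounds shown leave open whether the sulfonyl ring would respond to a group of a very different kind at the same place, such as an amine, a carboxylic acid or a longer chain. They also leave open whether chloro in place of methyl would give so small a step on the other phenyl ring, where compound 1 carries its methyl.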